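Swapping a chlorophenyl for pyrrole on a thiosemicarbazone

This account rests on a few compounds, and the source may have more. Where it says the series, first, only, none or still open, it means among the compounds named here.

Compound 3 `CC1=CC[C@H](C(C)(C)NC(=S)N/N=C/c2ccccc2Cl)CC1` carries a 2-chlorophenyl group on the carbon with a double bond to nitrogen. In a functional assay on NCI/ADR-RES cells (Homo sapiens) for inhibition, read by sulforhodamine B assay, with a stated time of 48 h (a lower number here means a stronger inhibitor of growth, a higher number a weaker inhibitor of growth), compound 3 gives 75000 nM. On the numbers shown, compound 3 sits second highest of three: compound 2 `CC1=CC[C@H](C(C)(C)NC(=S)N/N=C/c2ccc(O)cc2)CC1` gives 82100 nM and compound 1 `CC1=CC[C@H](C(C)(C)NC(=S)NN)CC1` gives 39300 nM, and all three numbers lie within the scatter of one another. Compound 4 `CC1=CC[C@H](C(C)(C)NC(=S)N/N=C/c2ccc[nH]2)CC1` differs by 1H-pyrrol-2-yl in place of 2-chlorophenyl on a carbon with a double bond to nitrogen. Among the measured compounds shown here, the only measured step at this position, a 1.1-fold lower number from compound 2 to compound 3 (0.04 log units; within the scatter), stayed within the scatter, and no measured compound with a pyrrole exists to draw on. The expected step is therefore none beyond the scatter, a 1.3-fold lower number from compound 3 to compound 4 (0.10 log units; within the scatter). Compound 4 is estimated at 60000 nM, in a range from 25000 nM to 150000 nM.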

Compound 4, concentration for 50% growth inhibition: 78000 nM
For compound 4 the middle estimate is 1.3-fold (0.11 log units) below the measured one; the measured number falls inside the stated range.
By their numbers in this assay, from the lowest: compounds 1, 3, 4 and 2 (each within the scatter of the next, the first and the last beyond it).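

In this assay, the 1H-pyrrol-2-yl group, with its five-membered ring and hydrogen-bond donor, reads the same within the scatter as 2-chlorophenyl (a 1.0-fold higher number from compound 3 to compound 4 (0.02 log units; within the scatter)) and 4-hydroxyphenyl (a 1.1-fold lower number from compound 2 to compound 4 (0.02 log units; within the scatter)). The larger change, adding the whole group with its linking carbon to the core of compound 1, also stays within the scatter (a 2.0-fold higher number from compound 1 to compound 4 (0.30 log units; within the scatter)). No supporting measurement helps explain this result.

On these data alone, whether a different group at this place, such as an aminomethyl or a carboxylic acid, would give a step beyond the scatter remains open.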